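Trimming the ketone arm: furan-2-yl to methyl

The source may report more compounds than this note shows. Statements on the series, on what has been measured and on what is new or still open speak of the compounds shown alone.

Within the data shown here, the three compounds measured so far share one core and differ in the group carried on the ketone that hangs from the double-bonded chain carbon. In a functional assay on A-375 cells (Homo sapiens) for cytotoxicity, read by MTT assay, with a stated time of 48 h (on this read-out higher numbers stand for weaker inhibition and lower numbers for stronger inhibition), compound 1 `CC1(C)S[C@@H]2/C(=C\C(=O)c3ccco3)C(=O)N2[C@H]1C(=O)OC(c1ccccc1)c1ccccc1` gives 26000 nM. Compound 2 `CC1(C)[C@H](C(=O)OC(c2ccccc2)c2ccccc2)N2C(=O)/C(=C/C(=O)c3ccccc3)[C@H]2S1(=O)=O` gives 17500 nM in this assay, and compound 3 `CC1(C)[C@H](C(=O)OC(c2ccccc2)c2ccccc2)N2C(=O)/C(=C/C(=O)c3ccc([N+](=O)[O-])cc3)[C@H]2[S+]1[O-]` gives 48200 nM. All three numbers sit within the usual scatter of one another, so compound 1 stands in the middle of a narrow spread with nothing separating it from its neighbours. Compound 4 `CC(=O)/C=C1/C(=O)N2[C@@H]1SC(C)(C)[C@@H]2C(=O)OC(c1ccccc1)c1ccccc1` differs from compound 1 by methyl in place of furan-2-yl on a carbonyl carbon. Among the measured compounds shown here, no measured pair shows this change. The step from compound 1 to compound 4 is expected to be small, a 1.2-fold higher number from compound 1 to compound 4 (0.06 log units; within the scatter), in no clear direction beyond the scatter. Compound 4 is therefore estimated at 30000 nM, between 12000 nM and 80000 nM.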

Compound 4, half-maximal inhibitory concentration: 63000 nM
Beside the measured number, compound 4's estimate is 2.1-fold (0.32 log units) below it; measured number inside the range.
By their numbers in this assay, from the lowest: compounds 2, 1, 3 and 4 (each within the scatter of the next, the first and the last beyond it).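

Among these compounds, replacing furan-2-yl with methyl on a carbonyl carbon gives the first readable step at this position in this assay (a 2.4-fold higher number from compound 1 to compound 4 (0.38 log units; beyond the scatter)). The earlier compounds shown here differed from one another in more than one place and stayed within the scatter, whereas this single change shows that the group here can shift the number, with the smaller methyl giving the weaker inhibition. No measurement here explains the shift. Going by these compounds, whether an ethyl group, a longer chain or an amine at this place would behave more like furan-2-yl or methyl remains open.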